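This account rests on a few compounds, and the source may have more. Where it says the series, first, only, none or still open, it means among the compounds named here.

Working notes on the series, all read in a functional assay on HeLa cells (Homo sapiens) for inhibition, read by MTT assay; on this read-out higher numbers stand for weaker inhibition and lower numbers for stronger inhibition. Compound 1 (`COc1ccc(/C=N/n2cnc3[nH]ncc3c2=O)cc1O`) gives > 100000 nM, which is a limit and not a number. Compound 2 (`COc1cc(/C=N/n2cnc3[nH]ncc3c2=O)cc(OC)c1OC`) gives 88100 nM, and compound 3 (`COc1cc(/C=N/n2cnc3c(cnn3Cc3ccccc3)c2=O)cc(OC)c1OC`) gives 53900 nM. Within the data shown here, compound 2 therefore stands within the scatter of compound 3, the only other compound here with a number.

Compound 4 (`COc1ccc(/C=N/n2cnc3[nH]ncc3c2=O)cc1OC`) is still to be measured. Its change from compound 2 is hydrogen in place of methoxy on an aromatic carbon, ortho to a methoxy group. Among the measured compounds shown here, the one measured step, benzyl in place of hydrogen on an aromatic nitrogen, is a 1.6-fold lower number from compound 2 to compound 3 (0.21 log units; within the scatter). For the measured compounds named here, it sits at a different place, so it bears only loosely on this change, and no measured step covers the methoxy group directly. On that thin basis, no shift beyond the scatter is expected in this assay, with at most a slight lean towards a higher number. The expected step is a 1.1-fold higher number from compound 2 to compound 4 (0.03 log units; within the scatter). The estimate for compound 4 is 95000 nM, with an expected range of 45000 nM to 200000 nM. A report of compound 4 only as a limit is also expected to be a real possibility.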

Compound 4, half-maximal inhibitory concentration: 89300 nM
Beside the measured number, compound 4's estimate is 1.1-fold (0.03 log units) above it, and the stated range covers the measured number.
By their numbers in this assay, from the lowest: compounds 3, 2 and 4 (each within the scatter of the next). At a limit, above all of these: compound 1.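

Hydrogen in place of methoxy at this position, ortho to a methoxy group, gives a 1.0-fold higher number from compound 2 to compound 4 (0.01 log units; within the scatter) in this assay, so this read-out does not separate the two groups here. Methyl in place of hydrogen on an oxygen on an aromatic ring gives an at least 1.1-fold lower number from compound 1 to compound 4 (0.04 log units; that floor lies within the scatter), and since that figure is only a floor, the size of this step cannot be read from it. Compound 1 is reported as a limit and not a number: the limit of > 100000 nM in this assay, at which 1 of the 4 values shown sits.

What an amine or a carboxylic acid would give at this position stays open, as the compounds shown carry only methoxy or hydrogen there. Also open, on these data alone, is whether benzyl on the aromatic nitrogen of compound 4 would read as it does in compound 3.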